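From Fluoromethyl to Methoxymethyl on a Shared Chain

A few compounds are considered here, and "the series" means these few. Any claim that something is new, unique, unknown or untested is made for them only; others in the source may bear on it.

Values measured in a functional assay on HL-60 cells (Homo sapiens) for cytotoxicity, read by WST assay, with a stated time of 48 h; on this read-out lower numbers stand for stronger inhibition and higher numbers for weaker inhibition:
Compound 1 `COc1cc(C(c2ccc(O)c(OC)c2)[C@@H](C)[C@@H](C)CO)ccc1O`: > 100000 nM (a limit)
Compound 2 `COc1cc(C(c2ccc(O)c(OC)c2)[C@H](C)[C@H](C)CO)ccc1O`: > 100000 nM (a limit)
Compound 3 `COc1cc(C(c2ccc(O)c(OC)c2)[C@@H](C)[C@@H](C)CF)ccc1O`: 38000 nM

Among the compounds with values here, compound 3 carries the only true number of the three, and the other two values are limits. Compound 4 `COC[C@H](C)[C@@H](C)C(c1ccc(O)c(OC)c1)c1ccc(O)c(OC)c1` differs from it in one place: 2-(methoxymethyl)-1-methylpropyl in place of 2-(fluoromethyl)-1-methylpropyl on a saturated chain carbon bound to two aromatic carbons. Here, 2-(methoxymethyl)-1-methylpropyl stands in place of 2-(fluoromethyl)-1-methylpropyl. The nearest evidence is an at least 2.6-fold lower number from compound 1 to compound 3 (0.42 log units; beyond the scatter) and an at least 2.6-fold lower number from compound 2 to compound 3 (0.42 log units; beyond the scatter), both measured from a limit, and neither tests a methoxymethyl group. A small step toward a higher number is therefore expected in this assay, estimated as a 1.4-fold higher number from compound 3 to compound 4 (0.16 log units; within the scatter). The estimate for compound 4 is 55000 nM, with an expected range of 20000 nM to 100000 nM.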

Compound 4, half-maximal inhibitory concentration: 68000 nM
Estimate against measurement, compound 4: 1.2-fold (0.09 log units) below, and the stated range covers the measured number.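

In this assay, the methoxymethyl and fluoromethyl chains on this saturated chain carbon read alike, with a 1.8-fold higher number from compound 3 to compound 4 (0.25 log units; within the scatter) showing no change beyond the scatter. Against the hydroxy compounds, an at least 1.4-fold lower number from compound 1 to compound 4 (0.16 log units; that floor lies within the scatter) and an at least 1.4-fold lower number from compound 2 to compound 4 (0.16 log units; that floor lies within the scatter) are only floors within the scatter, so compound 4, unlike compound 3, is not shown to differ from either. Both of these steps start from a limit: the limit of > 100000 nM in this assay, at which 2 of the 4 values shown sit.

Going by these compounds, whether an amine or a carboxylic acid at the end of this chain would move the number clearly away from that of compound 3 remains open. So does whether the mirror image of compound 3 or of compound 4 would read the same.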